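The source may report more compounds than this note shows. Statements on the series, on what has been measured and on what is new or still open speak of the compounds shown alone.

Measured in an ADME assay on Huh7.5.1 cells (Homo sapiens) for cytotoxicity, read by ATP content, with a stated time of 48 h; a lower number here means that less compound is tolerated, a higher number that more compound is tolerated:
- compound 1 `CC[C@@H]1C[C@H](CC)CN(CCCNC(=O)C2CCN(Cc3nc(-c4ccccc4C)oc3C)CC2)C1`: 3470 nM
- compound 2 `Cc1ccccc1-c1nc(CN2CCC(C(=O)NCCCN3CCCC(C(C)C)C3)CC2)c(C)o1`: 5820 nM

Only these two numbers exist so far, and compound 2 lies within the scatter of compound 1. Compound 3 `Cc1ccccc1-c1nc(CN2CCC(C(=O)NCCCCN3C[C@H](C)C[C@H](C)C3)CC2)c(C)o1` has the same atoms as compound 2, joined differently: a group of 9 heavy atoms (8 carbon, 1 nitrogen; one six-membered non-aromatic ring with 1 hetero atom) in place of a group of 9 heavy atoms (8 carbon, 1 nitrogen; one six-membered non-aromatic ring with 1 hetero atom), on a saturated chain carbon, three bonds along the chain from an amide-type nitrogen. The group that enters is (3,5-dimethylpiperidin-1-yl)methyl, with 2 defined stereocentres. Among the measured compounds shown here, one measured step bears on this change, as it falls at the same place on the saturated chain: a 1.7-fold higher number from compound 1 to compound 2 (0.22 log units; within the scatter). For the measured compounds named here, with that step as the only guide, no step beyond the scatter is expected in this assay, and no direction can be argued with confidence. The expected change is a 1.3-fold lower number from compound 2 to compound 3 (0.11 log units; within the scatter). For compound 3 the estimated value is 4500 nM, with an expected range from 2200 nM to 9000 nM.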

Compound 3, half-maximal cytotoxic concentration: 23100 nM
Estimate against measurement, compound 3: 5.1-fold (0.71 log units) below; measured number outside the range, above it.
By their numbers in this assay, from the lowest: compounds 1 and 2 (each within the scatter of the next); then compound 3.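

In this assay, this position now shows a step beyond the scatter: a 4.0-fold higher number from compound 2 to compound 3 (0.60 log units; beyond the scatter), even though the two compounds hold the same atoms, joined differently, and the group that leaves and the group that enters have the same counts of heavy atoms, donors and acceptors. The step of a 6.7-fold higher number from compound 1 to compound 3 (0.82 log units; beyond the scatter) is also beyond the scatter, and it sets (3,5-dimethylpiperidin-1-yl)methyl in place of 3,5-diethylpiperidin-1-yl at this same place on the saturated chain, so the tolerated concentration here responds to how the group is built, not only to what it contains. Nothing measured here accounts for either step.

As far as these compounds go, whether a morpholin-4-yl or an unsubstituted piperidin-1-yl group at this place would follow compound 3 or stay with compound 1 and compound 2 remains open. From the compounds shown here alone, the effect of the other stereoisomers of the (3,5-dimethylpiperidin-1-yl)methyl group also remains open.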